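A few compounds are considered here, and "the series" means these few. Any claim that something is new, unique, unknown or untested is made for them only; others in the source may bear on it.

Measured so far in a functional assay on DU-145 cells (Homo sapiens) for inhibition, read by trypan blue exclusion, with a stated time of 96 h; on this read-out higher numbers stand for weaker inhibition of growth and lower numbers for stronger inhibition of growth (concentration for half-maximal growth inhibition):
- compound 1 `Cc1ccc(CS/C(=C/c2cc(C)ccc2C)C(=O)c2ccc(Cl)cc2)cc1` gives 10000 nM 
- compound 2 `Cc1ccc(CS/C(=C/c2c[nH]c3ccc(Br)cc23)C(=O)c2ccc(Cl)cc2)cc1` gives 1000 nM 
- compound 3 `COc1ccccc1/C=C(/SCc1ccc(F)cc1)C(=O)c1ccc(Cl)cc1` gives 10000 nM 

Compound 3 stands at 10000 nM and is level with compound 1. Together they hold the highest of the three numbers, and compound 2 lies furthest off.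

Compound 4 `COc1ccccc1/C=C(/SCc1ccc(C)cc1)C(=O)c1ccc(Cl)cc1` differs from compound 3 by one exchange, methyl in place of fluoro on an aromatic carbon (methyl in place of fluoro on an aromatic carbon, para to a large group). Among the compounds with values here, the only measured step, a 10-fold lower number from compound 1 to compound 2 (1.00 log units; beyond the scatter), is modest and concerns a different group, 5-bromo-1H-indol-3-yl in place of 2,5-dimethylphenyl. It bears on this exchange only indirectly. Compound 1 (10000 nM) already carries the 4-methylbenzyl group and shows the same number as compound 3, though the two also differ elsewhere. Within the data shown here, no measured pair isolates the exchange.

No step beyond the scatter is therefore expected in this assay, and no direction is favoured. The expected step is small (a 1.3-fold lower number from compound 3 to compound 4 (0.10 log units; within the scatter)). Compound 4 is estimated at 8000 nM, with an expected range from 3000 nM to 20000 nM.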

Compound 4, concentration for 50% growth inhibition: 10000 nM
The estimate for compound 4 lay 1.3-fold (0.10 log units) below the measured number; the range from low to high includes it.
By their numbers in this assay, from the lowest: compound 2; then compounds 1, 3 and 4 (each within the scatter of the next).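

Methyl in place of fluoro on an aromatic carbon, para to a large group, gives no change at the digits printed from compound 3 to compound 4 (within the scatter) in this assay, the first reading that isolates this position; here 4-fluorobenzyl and 4-methylbenzyl cannot be told apart. With 4-methylbenzyl held fixed, 2-methoxyphenyl in place of 2,5-dimethylphenyl gives no change at the digits printed from compound 1 to compound 4 (within the scatter), whereas 2-methoxyphenyl in place of 5-bromo-1H-indol-3-yl gives a 10-fold higher number from compound 2 to compound 4 (1.00 log units; beyond the scatter). Among these single exchanges, only the one involving the 5-bromo-1H-indol-3-yl group moves the number beyond the scatter, while the benzyl exchange does not.

From the compounds shown here alone, whether methyl and fluoro also read alike with the 5-bromo-1H-indol-3-yl group in place, and whether an amine or a carboxylic acid on this aromatic carbon would shift the number, stays open. No available evidence accounts for these readings.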